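A few compounds are considered here, and "the series" means these few. Any claim that something is new, unique, unknown or untested is made for them only; others in the source may bear on it.

Measured so far in an assay on HEK293 cells for displacement of a labelled ligand from growth hormone secretagogue receptor type 1 (Homo sapiens), with a stated time of 60 min; on this read-out higher numbers stand for weaker inhibition and lower numbers for stronger inhibition:
- compound 1 `COCCNCCCS(=O)(=O)c1ccc2nc(NC(=O)NC(=O)c3ccccc3Cl)sc2c1` gives 8.6 nM
- compound 2 `CCN(CC)CCCS(=O)(=O)c1ccc2nc(NC(=O)NC(=O)c3ccccc3Cl)sc2c1` gives 13 nM

Compound 2 holds the highest of the two numbers in this assay; its nearest neighbour is compound 1, and the step of a 1.5-fold higher number from compound 1 to compound 2 (0.18 log units; within the scatter) lies within the scatter, so the two cannot be ordered.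

Compound 3 `CC(C)NCCS(=O)(=O)c1ccc2nc(NC(=O)NC(=O)c3ccccc3Cl)sc2c1` is not yet measured. It differs from compound 2 by isopropylamino in place of (diethylamino)methyl on a saturated chain carbon, two bonds along the chain from a sulfonyl sulfur. Going by the values given here, only one measured step bears on this: a 1.5-fold higher number from compound 1 to compound 2 (0.18 log units; within the scatter), which exchanged one amine for another at the far end of the chain without leaving the scatter. That step carries no information on shortening the chain itself, and the amine of compound 3 brings a hydrogen-bond donor that neither amine of the measured pair has. Among the compounds with values here, with no measured step for either of these changes, the expectation is of a step of no more than modest size, in either direction, and most likely within the scatter; a 1.2-fold higher number from compound 2 to compound 3 (0.06 log units; within the scatter) is the estimated step. Compound 3 is therefore expected to give about 15 nM in this assay, within a range from 5 nM to 45 nM.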

Compound 3, half-maximal inhibitory concentration in the growth hormone secretagogue receptor type 1 assay: 27 nM
For compound 3 the middle estimate is 1.8-fold (0.26 log units) below the measured one; measured number inside the range.
By their numbers in the growth hormone secretagogue receptor type 1 assay, from the lowest: compounds 1 and 2 (each within the scatter of the next); then compound 3.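

In the growth hormone secretagogue receptor type 1 assay, going from 3-(diethylamino)propyl to 2-(isopropylamino)ethyl gives a 2.1-fold higher number from compound 2 to compound 3 (0.32 log units; beyond the scatter), and the exchange against the (2-methoxyethyl)amino chain gives a 3.1-fold higher number from compound 1 to compound 3 (0.50 log units; beyond the scatter). Both steps are modest but leave the scatter, whereas exchanging one amine for another at the end of the longer chain did not: a 1.5-fold higher number from compound 1 to compound 2 (0.18 log units; within the scatter). In a physicochemical assay for solubility, at pH 7.4 (a lower number here means a less soluble compound, a higher number a more soluble compound), compound 2 gives 280000 nM and compound 3 gives 71000 nM. The same exchange also lowers the number in the physicochemical assay, so compound 3 falls behind compound 2 on both read-outs: the measured solubility of compound 2, 280000 nM, and of compound 3, 71000 nM, a 3.9-fold lower number (0.60 log units; beyond the scatter)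

Chain length and the amine change together in both new steps, so neither step can be assigned to one or the other; a 3-(isopropylamino)propyl chain or a 2-(diethylamino)ethyl chain on the shared core would separate the two. Also open is how a ring amine such as morpholine, or a longer chain carrying either amine, would read in the growth hormone secretagogue receptor type 1 assay and in the physicochemical assay, since the three compounds shown cover only a narrow part of this position.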